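Stilbene-like isoxazoles and pyrazoles: cytotoxicity notes

A few compounds are considered here, and "the series" means these few. Any claim that something is new, unique, unknown or untested is made for them only; others in the source may bear on it.

Measured so far:
- compound 1 `COc1ccc(/C=C/c2cc(C)n[nH]2)cc1`: 9400 nM
- compound 2 `COc1cc(/C=C/c2cc(C)no2)ccc1O`: 33400 nM

In a functional assay on HCT-116 cells (Homo sapiens) for cytotoxicity, read by MTT assay, with a stated time of 72 h (on this read-out lower numbers stand for stronger inhibition and higher numbers for weaker inhibition), compound 2 gives 33400 nM, the highest number of the two; compound 1 gives 9400 nM, a gap beyond the scatter. Compound 3 `Cc1cc(/C=C/c2ccc(O)cc2)on1` differs from compound 2 by hydrogen in place of methoxy on an aromatic carbon. Within the data shown here, no measured pair isolates this change, so the step from compound 2 to compound 3 in this assay cannot be anchored; the expectation is a small step, if any, toward a lower number, and possibly none beyond the scatter, as a 1.3-fold lower number from compound 2 to compound 3 (0.13 log units; within the scatter). Compound 3 is estimated at 25000 nM, with a range of 9000 nM to 70000 nM.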

Compound 3, half-maximal inhibitory concentration: 67900 nM
The estimate for compound 3 lay 2.7-fold (0.43 log units) below the measured number; the measured number falls inside the stated range.
By their numbers in this assay, from the lowest: compound 1; then compound 2; then compound 3.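

In this assay, among these compounds, hydrogen in place of methoxy, ortho to a hydroxy group, gives a 2.0-fold higher number from compound 2 to compound 3 (0.31 log units; beyond the scatter) as the first single-place step. At this position, with the hydroxy group kept, methoxy therefore goes with the lower number and hydrogen with the higher one. No measurement at hand bears on the reason for this step. Still open, as far as these compounds go, is whether an amine or a longer alkoxy chain at this position would lower the number further. Also open, from the compounds shown here alone, is whether the same step would appear on a core carrying a pyrazole in place of the isoxazole.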